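The compounds below may be only part of what the source reports. "The series", "measured", "known", "first", "only" and "open" are said of these compounds alone.

In a functional assay on RAW264.7 cells (Mus musculus), with a stated time of 3 days (on this read-out lower numbers stand for stronger inhibition and higher numbers for weaker inhibition), compound 1 (`COc1cnc(-c2ccccn2)nc1C1CCCC1`) gives 1800 nM, the highest of the three numbers in hand and beyond the scatter from the other two. Compound 2 (`COc1cnc(-c2ccccn2)nc1NCc1ccccc1F`) gives 130 nM, and compound 3 (`COc1cnc(-c2ccccn2)nc1NCc1ccc(F)cc1F`) gives 110 nM. Among the measured compounds shown here, the only measured step is a 1.2-fold lower number from compound 2 to compound 3 (0.07 log units; within the scatter), which is fluoro in place of hydrogen on an aromatic carbon. It lies within the scatter and does not touch the group in question here.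

Compound 4 (`COc1cnc(-c2ccccn2)nc1N1CCCC1`) is the core of compound 1 with pyrrolidin-1-yl in place of cyclopentyl on an aromatic carbon. For the measured compounds named here, no measured step covers this exchange, so any expectation is loose. Going by the values given here, the one indirect guide is that compound 2, at 130 nM, also holds its substituent on that carbon through nitrogen, as does compound 3, at 110 nM. Both differ from compound 4 in carrying a fluorinated benzyl group, so only part of their distance from compound 1 is expected to carry over.

The expected step is a 3.6-fold lower number from compound 1 to compound 4 (0.56 log units; beyond the scatter), in the direction of stronger inhibition in this assay. For compound 4 the estimated value is 500 nM, with an expected range of 130 nM to 2000 nM.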

Compound 4, half-maximal inhibitory concentration: 150 nM
Estimate against measurement, compound 4: 3.3-fold (0.52 log units) above; the measured number falls inside the stated range.
By their numbers in this assay, from the lowest: compounds 3, 2 and 4 (each within the scatter of the next); then compound 1.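

In this assay, keeping the five-membered non-aromatic ring and its 5 heavy atoms while putting pyrrolidin-1-yl in place of cyclopentyl gives a 12-fold lower number from compound 1 to compound 4 (1.08 log units; beyond the scatter), so the step at this carbon is large even though the two groups match in heavy-atom count and differ by 1 nitrogen and 1 hydrogen-bond acceptor. Compound 4 at 150 nM is also within the scatter of compound 2 at 130 nM and thus shows that a fluorinated benzyl group is not required for a value at this level; among the compounds shown, all three with nitrogen on this carbon lie beyond the scatter from compound 1, and none goes against this. Nothing available accounts for the size of the step.

Open, going by these compounds, is whether any nitrogen-linked group at this place holds this level or whether it is particular to pyrrolidin-1-yl; piperidin-1-yl, morpholin-4-yl and an open-chain dimethylamino group would each test this. Also open, on these data alone, is whether the step carries over to a core with a group other than methoxy or pyridin-2-yl, such as an ethoxy group in place of methoxy.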